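The source may hold more compounds than are shown below. What is called first, only, known or untested is meant among the compounds shown, and "the series" means these compounds.

Measured compounds in an ADME assay on NIH3T3 cells (Mus musculus) for cytotoxicity; on this read-out higher numbers stand for lower toxicity in this test and lower numbers for higher toxicity in this test:

Compound 1 `CCOC(=O)CN(C)CC#Cc1cc2ncnc(Nc3ccc(OCc4cccc(F)c4)c(Cl)c3)c2s1`: 52 uM
Compound 2 `CC(C)(C)CC#Cc1cc2ncnc(Nc3ccc(OCc4cccc(F)c4)c(Cl)c3)c2s1`: > 50 uM, a limit of the assay, not a number.
Compound 3 `CCOC(=O)CN(C)CC#Cc1cc2c(Nc3ccc(OCc4cccc(F)c4)c(Cl)c3)ncnc2s1`: > 50 uM, likewise a limit of the assay.

Compounds 1 and 2 share one core; compound 3 and the unmeasured compound 4 `CC(C)(C)CC#Cc1cc2c(Nc3ccc(OCc4cccc(F)c4)c(Cl)c3)ncnc2s1` share a second core built from the same atoms joined differently. How the two cores differ is not broken down here.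

Within the first core, the change from compound 1 to compound 2 is tert-butyl in place of ((ethoxycarbonyl)methyl)(methyl)amino on a saturated chain carbon bound to a triple-bonded carbon. Its step is a step that the limit leaves unreadable from compound 1 to compound 2; the limit for compound 2 keeps its size from being read. What the pair shows is a numbered value for compound 1 and only a limit for compound 2.

The same change, at the same place, is made on the second core: from compound 3 to compound 4 the difference is tert-butyl in place of ((ethoxycarbonyl)methyl)(methyl)amino on a saturated chain carbon bound to a triple-bonded carbon. Compound 3 already sits at the limit, so the step cannot be read from a numbered value either. The expectation rests on the limit of > 50 uM in this assay, at which 2 of the 3 values shown sit: with the starting point at the limit and the same change having given a limit once before, compound 4 is expected to come out at the limit too, so the estimated step is a step that the limit leaves unreadable from compound 3 to compound 4. Compound 4 is estimated at 60 uM in this assay, with a range from 30 uM to 150 uM.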

Compound 4, half-maximal toxic concentration: > 50 uM
Compound 4 ended at the assay's limit; the forecaster's own chance of this, stated with the estimate: 70%; the middle value is on the limit's open side.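

No new step can be read: compound 3 and compound 4 both stand at a limit of this assay, not at a number, and the step between them stays unreadable: the limit of > 50 uM in this assay, at which 3 of the 4 values shown sit.

Left open is where compound 2, compound 3 and compound 4 lie beyond that limit, and so whether tert-butyl in place of ((ethoxycarbonyl)methyl)(methyl)amino changes the read-out on either core.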